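The source may hold more compounds than are shown below. What is called first, only, known or untested is meant among the compounds shown, and "the series" means these compounds.

Three compounds have been measured in a functional assay on Caco-2 cells (Homo sapiens) for inhibition, read by sulforhodamine B assay, with a stated time of 72 h; on this read-out higher numbers stand for weaker inhibition and lower numbers for stronger inhibition:

- compound 1 `COc1cc(/C=C/C(=O)/C=C(/C=C/c2ccc(OC(C)=O)c(OC)c2)NC2CCCCC2)ccc1OC(C)=O`: 4400 nM
- compound 2 `CCCNC(=C\C(=O)/C=C/c1ccc(O)c(OC)c1)/C=C/c1ccc(O)c(OC)c1`: 22000 nM
- compound 3 `COc1cc(/C=C/C(=O)CC(=O)/C=C/c2ccc(OC(C)=O)c(OC)c2)ccc1OC(C)=O`: > 25000 nM

For compound 3, this entry is a limit of the assay and not a number.

For the measured compounds named here, that leaves only two true numbers to compare. Compound 2, at 22000 nM, has the higher one and so the weaker inhibition. Compound 1 sits lower at 4400 nM, and this gap lies beyond the usual scatter of repeated measurements.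

The next compound to test is compound 4 `COc1cc(/C=C/C(=O)/C=C(/C=C/c2ccc(O)c(OC)c2)NC2CCCCC2)ccc1O`. It differs from compound 2 by having cyclohexyl in place of propyl on an amine nitrogen.

Going by the values given here, no measured pair isolates this change. The closest guide is compound 1, which also carries cyclohexyl on an amine nitrogen and gives 4400 nM, but it differs from compound 4 elsewhere as well. A moderate fall in the number, meaning stronger inhibition, is therefore expected, though perhaps not the whole gap seen between the two measured values. The expected change is a 2.4-fold lower number from compound 2 to compound 4 (0.39 log units; beyond the scatter). For compound 4 the estimate is 9000 nM, with an expected range of 3500 nM to 22000 nM.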

Compound 4, half-maximal inhibitory concentration: 5100 nM
Compound 4: the middle estimate sits 1.8-fold (0.25 log units) above what was measured, within the range that was stated.
By their numbers in this assay, from the lowest: compounds 1 and 4 (each within the scatter of the next); then compound 2. At a limit, above all of these: compound 3.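

Swapping propyl for cyclohexyl on the amine nitrogen gives a 4.3-fold lower number from compound 2 to compound 4 (0.63 log units; beyond the scatter) in this assay. For the compounds shown here, nothing else differs between these two structures, so this is the first measured pair that isolates a change at this position, and it shows that inhibition grows stronger, not weaker, when the nitrogen carries a six-membered ring of carbon in place of a three-carbon chain. The step is modest, and as a single pair it gives a direction for these two groups only, not a trend across the position.

The compounds shown leave open whether the ring itself matters or simply the added carbons, a question that a straight hexyl chain on the same nitrogen could address, and how a phenyl group or a chain ending in a carboxylic acid would read at this position. Compound 3 is a limit and not a number, so it offers no step to compare with this one: the limit of > 25000 nM in this assay, at which 1 of the 4 values shown sits.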